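A few compounds are considered here, and "the series" means these few. Any claim that something is new, unique, unknown or untested is made for them only; others in the source may bear on it.

Measured in a functional assay on BT-474 cells (Homo sapiens) for inhibition, read by fluorescence, with a stated time of 72 h; a higher number here means a weaker inhibitor of growth, a lower number a stronger inhibitor of growth:
- Compound 1 `CCCCCCn1cnc2c(Nc3ccc(Cl)cc3)nc(N[C@H]3CC[C@H](N)CC3)nc21`: 5500 nM
- Compound 2 `COc1cc(Nc2nc(N[C@H]3CC[C@H](N)CC3)nc3c2ncn3CCC(C)C)cc(OC)c1`: 5900 nM

Compound 2, at 5900 nM, lies within the usual scatter of compound 1, so the two measured compounds cannot be ranked on these numbers. Compound 3 `CCCCCCn1cnc2c(Nc3cc(OC)cc(OC)c3)nc(N[C@H]3CC[C@H](N)CC3)nc21` has not yet been measured in this assay. It differs from compound 2 by butyl in place of isopropyl on a saturated chain carbon, two bonds along the chain from an aromatic nitrogen, with butyl in place of isopropyl on a saturated chain carbon, two bonds along the chain from an aromatic nitrogen. The same difference can also be read as isopentyl to hexyl. Going by the values given here, no measured pair differs in one place only, so the data give no direct size for such a change. No step beyond the scatter is expected in this assay, in either direction. The expected step is a 1.2-fold lower number from compound 2 to compound 3 (0.07 log units; within the scatter). For compound 3 the estimated value is 5000 nM, with an expected range from 2500 nM to 10000 nM.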

Compound 3, concentration for 50% growth inhibition: 3700 nM
The estimate for compound 3 lay 1.4-fold (0.13 log units) above the measured number; the range from low to high includes it.
By their numbers in this assay, from the lowest: compounds 3, 1 and 2 (each within the scatter of the next).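

With compound 3, this assay gains its first steps that can be read, one for each of two single changes. Butyl in place of isopropyl on a saturated chain carbon, two bonds along the chain from an aromatic nitrogen, gives a 1.6-fold lower number from compound 2 to compound 3 (0.20 log units; within the scatter) on the chain side, and 3,5-dimethoxyphenyl in place of 4-chlorophenyl on a nitrogen on an aromatic ring gives a 1.5-fold lower number from compound 1 to compound 3 (0.17 log units; within the scatter) on the other side, so neither change separates its pair in this read-out. Nothing shown here accounts for these numbers.

Still open, on these data alone, is whether a chain longer than hexyl, or one ending in an amine or a carboxylic acid, would move the number beyond the scatter. As far as these compounds go, each change is also seen only once, so whether the chain change would give a similar step with 4-chlorophenyl on the nitrogen remains unknown.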